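Methylene-sugar nucleosides with a methoxy for dimethylamino swap

The source may report more compounds than this note shows. Statements on the series, on what has been measured and on what is new or still open speak of the compounds shown alone.

Measured so far, in a functional assay on MT4 cells (Homo sapiens) for inhibition; on this read-out higher numbers stand for weaker inhibition and lower numbers for stronger inhibition:
Compound 1, `C=C1[C@@H](O)[C@H](n2cnc3c(N(C)C)nc(N)nc32)O[C@@H]1CO`, gives > 500000 nM, which is a limit of the assay rather than a number.
Compound 2, `C=C1[C@@H](O)[C@H](n2cnc3c(OC)nc(N)nc32)O[C@@H]1CO`, gives > 500000 nM, also a limit.
Compound 3, `C=C1[C@H](n2cnc3c(N(C)C)nc(N)nc32)O[C@H](CO)[C@H]1O`, gives > 500000 nM, again a limit.

All three values sit at the same point, (the limit of > 500000 nM in this assay, at which 3 of the 3 values shown sit), so none of the compounds can be said to inhibit more or less strongly than another. The change from compound 1 to compound 2 is methoxy in place of dimethylamino on an aromatic carbon; its step, a step that the two limits leave unreadable from compound 1 to compound 2, cannot be read because both ends are limits. Compound 3 and compound 1 share the same atoms joined differently; the difference between the two cores is not broken down here.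

Compound 4, `C=C1[C@H](n2cnc3c(OC)nc(N)nc32)O[C@H](CO)[C@H]1O`, is not yet measured. It arises from compound 3 by methoxy in place of dimethylamino on an aromatic carbon, the same change as from compound 1 to compound 2. Since compound 1 and compound 2 both stand at the limit, compound 4 is expected to stay there too, with an estimated step of a number no higher from compound 3 to compound 4 (the limit leaves the size open). The estimate for compound 4 in this assay is 500000 nM, most likely reported only as a limit.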

Compound 4, half-maximal inhibitory concentration: 180000 nM
Estimate against measurement, compound 4: 2.8-fold (0.44 log units) above, outside the stated range (below it).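

In this assay, methoxy in place of dimethylamino on an aromatic carbon gives an at least 2.7-fold lower number from compound 3 to compound 4 (0.44 log units; beyond the scatter), so on the core of compound 3 this change leads to a readable number where there was only a limit. On the core of compound 1, the same change gives no readable step, and no size can be assigned to it: the limit of > 500000 nM in this assay, at which 3 of the 4 values shown sit.

Going by these compounds, the result therefore neither shows that the change carries over between the two cores nor shows that it fails to do so, and the exact size of the step on the core of compound 3 also stays open.

The compounds shown leave open whether the lower number is particular to methoxy, or whether another group on the same aromatic carbon, such as ethoxy or a plain amino group, would also bring the core of compound 3 off the limit. They also leave open how the core of compound 1 would respond to such groups.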